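A Methyl on the Outer Ring of Compound 1

The compounds below may be only part of what the source reports. "The series", "measured", "known", "first", "only" and "open" are said of these compounds alone.

Compound 1 `CC(C)C[C@H](N)CN(C(=O)[C@@H]1C[C@H]1c1ccccc1)c1ccc(-c2ccccc2)cc1`: 880 nM
Compound 2 `CC(C)[C@H](N)CN(C(=O)[C@@H]1C[C@H]1c1ccccc1)c1ccc(-c2ccccc2)cc1`: 1.1 nM
Compound 3 `CC(C)(C)[C@H](N)CN(C(=O)[C@@H]1C[C@H]1c1ccccc1)c1ccc(-c2ccccc2)cc1`: 11 nM

In a functional assay for agonist activity at G protein-coupled receptor 88 (Homo sapiens), read by HTRF and cAMP accumulation (on this read-out higher numbers stand for an effect only at larger amounts of compound and lower numbers for an effect already at smaller amounts), compound 1 stands highest of the three numbers: the steps are an 800-fold lower number from compound 1 to compound 2 (2.90 log units; beyond the scatter) and an 80-fold lower number from compound 1 to compound 3 (1.90 log units; beyond the scatter), while between the other two the step is a 10-fold higher number from compound 2 to compound 3 (1.00 log units; beyond the scatter). All three steps change the group on the saturated chain carbon bound to the amine nitrogen.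

Compound 4 `Cc1ccc(-c2ccc(N(C[C@@H](N)CC(C)C)C(=O)[C@@H]3C[C@H]3c3ccccc3)cc2)cc1` differs from compound 1 elsewhere: methyl in place of hydrogen on an aromatic carbon. For the measured compounds named here, no measured step touches an aromatic carbon, so none bears on this change, and no step beyond the scatter is expected. Compound 4 is therefore estimated at 880 nM in this assay, within 300 nM to 2600 nM, which amounts to an expected no change at the digits printed from compound 1 to compound 4 (within the scatter).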

Compound 4, half-maximal effective concentration: 360 nM
Estimate against measurement, compound 4: 2.4-fold (0.39 log units) above; the range from low to high includes it.
By their numbers in this assay, from the lowest: compound 2; then compound 3; then compound 4; then compound 1.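

This is the only step shown at an aromatic carbon, and it shows that this position is not indifferent to change: phenyl to 4-methylphenyl gives a 2.4-fold lower number from compound 1 to compound 4 (0.39 log units; beyond the scatter) in this assay as a modest shift. For the compounds shown here, the methyl sits on a six-membered aromatic ring, para to a large group, far from the chain carbon whose group changed in the earlier steps. No measurement here speaks to what lies behind this step.

As far as these compounds go, whether an ethyl, a methoxy or an amine at this carbon would move the number further remains open. So does whether the same methyl would shift compound 2, which carries isopropyl in place of isobutyl.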